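Removing a Fluorine From a Writhing-Test Inhibitor

The source may hold more compounds than are shown below. What is called first, only, known or untested is meant among the compounds shown, and "the series" means these compounds.

Measured so far:
Compound 1 `Cc1c(C=O)cc(-c2ccc(S(C)(=O)=O)cc2)n1-c1ccc(F)c(F)c1` gives 60% in a functional assay on the whole organism (strain Swiss albino) for inhibition, with Mus musculus as the target, in the writhing test, with a stated time of 30 min, at a dose of 40 mg/kg by the oral route; on this read-out lower numbers stand for a weaker effect and higher numbers for a stronger effect at the one dose given
Compound 2 `Cc1c(/C=N\O)cc(-c2ccc(S(C)(=O)=O)cc2)n1-c1ccc(F)cc1` gives 47% in this assay

Among the measured compounds shown here, only two compounds have numbers, and they differ in more than one place, so no single step between them can be read. Compound 2 stands lowest of the two; the nearest number, that of compound 1, lies above it by more than the usual scatter of this kind of measurement, so the gap between them is a real one.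

The next compound to be measured is compound 3 `Cc1c(/C=N\O)cc(-c2ccc(S(C)(=O)=O)cc2)n1-c1ccccc1`, which is reached from compound 2 by one change: hydrogen in place of fluoro on an aromatic carbon. For the measured compounds named here, nothing measured so far shows what such a change does in this assay, since no pair of measured compounds differs only there. The change is small, a single fluorine giving way to hydrogen, and the rest of the molecule stays the same. The expected step from compound 2 to compound 3 is therefore a number 4 percentage points lower from compound 2 to compound 3 (within the scatter), a modest drift that may well stay within the scatter. For compound 3 the expected inhibition is 43%, with a likely range from 25% to 60%.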

Compound 3, a percentage reported as inhibition, in the whole organism at one dose (the size of the read-out at that dose, not a potency): 57%
For compound 3 the middle estimate is 14 percentage points below the measured one; the measured number falls inside the stated range.
By their numbers in this assay, from the lowest: compounds 2, 3 and 1 (each within the scatter of the next, the first and the last beyond it).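

Going from 4-fluorophenyl to phenyl gives, in this assay, a number 10 percentage points higher from compound 2 to compound 3 (within the scatter), and this is the first pair of compounds here that differs in only one place. At the one dose tested, compound 2 and compound 3 cannot be told apart, so the read-out gives no sign that the fluoro on this aromatic carbon matters: the effect is still present with hydrogen in its place, and this single pair is all that supports that reading. Nothing measured here explains the result, and no cause can be offered for it.

On these data alone, what a larger or different group would do on that same aromatic carbon remains open, whether a chlorine, a methoxy group or a trifluoromethyl group, as only fluoro and hydrogen are compared there. Also open is what the rest of the molecule contributes, since no pair shown isolates the oxime from the aldehyde of compound 1, and a read-out at one dose says nothing about potency.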